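This account rests on a few compounds, and the source may have more. Where it says the series, first, only, none or still open, it means among the compounds named here.

Measured compounds:
- Compound 2, `O=C(Nc1c(F)cc(F)cc1F)N(Cc1cccc(-c2cc[nH]n2)c1)C1CCCCCC1`: 22 nM
- Compound 3, `CN(C)c1ccc(CN(Cc2cccc(-c3cc[nH]n3)c2)C(=O)Nc2c(F)cc(F)cc2F)cc1`: 12 nM
- Compound 1, `Cc1cc(C)c(NC(=O)N(Cc2ccc(-c3ccccc3)s2)C2CCCCCC2)c(C)c1`: 46 nM

In an assay on microsomes from intestine for inhibition of acyl-CoA:cholesterol acyltransferase (Oryctolagus cuniculus) (on this read-out lower numbers stand for stronger inhibition and higher numbers for weaker inhibition), compound 2 stands second highest of the three numbers; the nearest is compound 3, with a 1.8-fold lower number from compound 2 to compound 3 (0.26 log units; within the scatter), and the furthest is compound 1, whose number lies beyond the scatter above that of compound 2. Compound 4, `Cc1cc(C)c(NC(=O)N(Cc2cccc(-c3cc[nH]n3)c2)C2CCCCCC2)c(C)c1`, differs from compound 2 by 2,4,6-trimethylphenyl in place of 2,4,6-trifluorophenyl on an amide-type nitrogen. Among the measured compounds shown here, no measured step tests this exact exchange. For the measured compounds named here, the one measured step, from compound 2 to compound 3, changes a different part and stays within the scatter. Compound 1 carries the same 2,4,6-trimethylphenyl group but on a different core, so its value only loosely bears on compound 4. For compound 4 a step of a 1.4-fold higher number from compound 2 to compound 4 (0.13 log units; within the scatter) is expected, giving an estimate of 30 nM with a range from 10 nM to 90 nM.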

Compound 4, half-maximal inhibitory concentration: 65 nM
Compound 4: middle estimate off by 2.2-fold (0.34 log units), on the low side; the range from low to high includes it.
By their numbers in this assay, from the lowest: compounds 3 and 2 (each within the scatter of the next); then compounds 1 and 4 (each within the scatter of the next).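

In this assay, this exchange now has a direct test on the shared core: a 3.0-fold higher number from compound 2 to compound 4 (0.47 log units; beyond the scatter). The step is modest but beyond the scatter, so 2,4,6-trimethylphenyl gives weaker inhibition than 2,4,6-trifluorophenyl on this amide-type nitrogen, even though both groups have the same number of heavy atoms and the same aromatic ring. Nothing available explains this difference. Still open, as far as these compounds go, is where chlorine or methoxy groups on this phenyl ring would fall, and whether the exchange gives a similar step in compound 3, which carries 4-(dimethylamino)benzyl in place of cycloheptyl.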